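Swapping a lactam ring for an amino group on the acid ring

This account rests on a few compounds, and the source may have more. Where it says the series, first, only, none or still open, it means among the compounds named here.

Compound 1, `Cc1ccc(-c2cc(Cl)ccc2OCc2ccc(F)cc2F)n1-c1cc(C(=O)O)ccc1F`, gives 6.31 nM in an assay on CHO cells for displacement of a labelled ligand from prostaglandin E2 receptor EP1 subtype (Homo sapiens); on this read-out lower numbers stand for stronger inhibition and higher numbers for weaker inhibition.
Compound 2, `Cc1ccc(-c2cc(Br)ccc2OCc2ccc(F)cc2F)n1-c1cc(C(=O)O)cc(N2CCCCC2=O)c1`, gives 1.26 nM in this assay.
Compound 3, `Cc1ccc(-c2cc(Cl)ccc2OCc2ccccc2)n1-c1cc(Br)cc(C(=O)O)c1`, gives 5.01 nM in this assay.

Among these three, compound 2 has the lowest number, and both gaps to its neighbours lie beyond the usual scatter: compound 3 sits well above it, and compound 1 further still. Compound 2 therefore counts as the strongest binder measured so far.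

Compound 4, `Cc1ccc(-c2cc(Br)ccc2OCc2ccc(F)cc2F)n1-c1cc(N)cc(C(=O)O)c1`, is the next compound to be tested. It differs from compound 2 in a single spot: amino in place of 2-oxopiperidin-1-yl on an aromatic carbon. In plain words, a six-membered ring group is taken off the acid-bearing ring and a small amino group is put in its place.

Within the data shown here, no directly comparable pair among the measured compounds covers this change, so the expected step in this assay rests on the surrounding numbers alone. Compounds 1 and 3, which carry nothing large at that spot, both sit clearly above compound 2, which suggests that removing the larger group is more likely to weaken binding than to strengthen it. The expected step from compound 2 to compound 4 is a moderate rise, a 3.2-fold higher number from compound 2 to compound 4 (0.50 log units; beyond the scatter). For compound 4 the estimate is 4 nM, with a plausible range from 1.5 nM to 12 nM.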

Compound 4, half-maximal inhibitory concentration: 0.501 nM
Compound 4: middle estimate off by 8.0-fold (0.90 log units), on the high side; the measured number lies below the stated range.
By their numbers in this assay, from the lowest: compound 4; then compound 2; then compounds 3 and 1 (each within the scatter of the next).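

In this assay the swap gives a 2.5-fold lower number from compound 2 to compound 4 (0.40 log units; beyond the scatter) and so shows that the 2-oxopiperidin-1-yl ring is not needed for strong binding at this spot on the acid-bearing ring. A much smaller amino group does better here, even though it leaves out the ring and the carbonyl and adds a hydrogen-bond donor. No measurement here accounts for the lower number.

This single swap cannot separate the effect of losing the ring from that of gaining the donor. A dimethylamino group, which has no hydrogen on its nitrogen, or a methyl group at the same spot would help tell these two changes apart, while an acetylamino group would test whether a carbonyl can be tolerated alongside that hydrogen.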